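Aryl amide swaps on the shared cyclopentyloxy core

The compounds below may be only part of what the source reports. "The series", "measured", "known", "first", "only" and "open" are said of these compounds alone.

Compound 1 `COc1ccc(C(=O)Nc2ccccc2Cl)cc1OC1CCCC1` gives 190 nM in an assay on isolated protein for inhibition of phosphodiesterase 4A (Sus scrofa); on this read-out higher numbers stand for weaker inhibition and lower numbers for stronger inhibition. Compound 2 `COc1ccc(C(=O)Nc2cnccn2)cc1OC1CCCC1` gives 250 nM in this assay, which is the highest of the two numbers seen so far; the nearest is compound 1, and the gap between them lies within the scatter, as the step of a 1.3-fold higher number from compound 1 to compound 2 (0.12 log units; within the scatter) shows. Compound 3 `COc1ccc(C(=O)Nc2ncccc2C)cc1OC1CCCC1` is not yet measured. It differs from compound 2 by 3-methylpyridin-2-yl in place of pyrazin-2-yl on an amide-type nitrogen. Among the compounds with values here, the one measured step that bears on this change is the one from compound 1 to compound 2, which also exchanges the aryl group on the amide-type nitrogen and remains within the scatter. On that basis no step beyond the scatter is expected for compound 3 in either direction, an expected step of a 1.1-fold lower number from compound 2 to compound 3 (0.06 log units; within the scatter). Compound 3 is therefore estimated at 220 nM in this assay, with a range of 110 nM to 450 nM.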

Compound 3, half-maximal inhibitory concentration: 3100 nM
The estimate for compound 3 lay 14-fold (1.15 log units) below the measured number, outside the stated range (above it).
By their numbers in this assay, from the lowest: compounds 1 and 2 (each within the scatter of the next); then compound 3.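

The aryl group on the amide-type nitrogen is less forgiving than the first pair suggested: in this assay, 3-methylpyridin-2-yl in place of pyrazin-2-yl gives a 12-fold higher number from compound 2 to compound 3 (1.09 log units; beyond the scatter) and in place of 2-chlorophenyl gives a 16-fold higher number from compound 1 to compound 3 (1.21 log units; beyond the scatter) as well. Exchange of this group can therefore weaken inhibition by a large step, although the change from 2-chlorophenyl to pyrazin-2-yl stayed within the scatter (a 1.3-fold higher number from compound 1 to compound 2 (0.12 log units; within the scatter)). No data at hand explain the loss.

As far as these compounds go, the swap from pyrazin-2-yl changes both the ring atoms and the methyl group, so the share of each in the step remains open. Plain pyridin-2-yl, without the methyl group, and 2-methylphenyl would separate the two.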